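Trading a Ketone Bridge for a Benzyl Link

The compounds below may be only part of what the source reports. "The series", "measured", "known", "first", "only" and "open" are said of these compounds alone.

The compounds share one core and were tested in a functional assay on the whole organism (strain CF-1) with Mus musculus as the target; a higher number here means that more compound is needed for the effect, a lower number that less compound is needed. Going by the values given here, compound 2 `Cc1nnc(CN2CCCC2)n1-c1ccc(Cl)cc1C(=O)c1ccccc1Cl` is the only one with a definite number: in this assay compound 2 gives 18 mg/kg. Compound 1 `Cc1nnc(CN2CCCC2)n1-c1ccc(Cl)cc1C(O)c1ccccc1` reached only a limit of the assay, giving > 25 mg/kg; > 200 mg/kg (2 entries). Compound 3 `CN(C)Cc1nnc(-c2ccncc2)n1-c1ccc(Cl)cc1C(=O)c1ccccc1Cl` likewise stopped at a limit of the assay, with > 100 mg/kg. Compound 2 therefore stands as the single measured point, flanked by the several entries of compound 1 in this assay, > 25 mg/kg; > 200 mg/kg (2 entries) and by the limit of > 100 mg/kg in this assay, at which 1 of the 3 values shown sits.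

Compound 4 `Cc1nnc(CN2CCCC2)n1-c1ccc(Cl)cc1Cc1ccccc1` is not yet measured. It differs from compound 2 in one place: benzyl in place of (2-chlorophenyl)carbonyl on an aromatic carbon. Among the compounds with values here, no measured pair differs in exactly this way, so the size of the step is open. Compound 1, which also lacks the carbonyl, reached only a limit, and its entries are > 25 mg/kg; > 200 mg/kg (2 entries). On that basis the step of a 3.3-fold higher number from compound 2 to compound 4 (0.52 log units; beyond the scatter) is expected to go toward a higher dose, beyond the usual scatter. Compound 4 is estimated at 60 mg/kg, with a range from 15 mg/kg to 250 mg/kg, and a fair chance that only a limit is reported.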

Compound 4, dose for half-maximal effect: > 100 mg/kg
Compound 4: only a limit was reported (the forecaster's own chance of this, stated with the estimate: 50%); middle value at least 1.6-fold (0.22 log units) away from the limit.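

Going by these compounds alone, this is the first one-place change that can be read at this position on the aromatic ring, and in this assay replacing (2-chlorophenyl)carbonyl with benzyl gives an at least 5.5-fold higher number from compound 2 to compound 4 (0.74 log units; beyond the scatter). Compound 4 reached only a limit of the assay: the limit of > 100 mg/kg in this assay, at which 2 of the 4 values shown sit. Among the compounds shown, only compound 2 gives a definite number, which links that number to the (2-chlorophenyl)carbonyl group, although compound 3 carries the same group and also stopped at a limit.

The change removes the carbonyl and the chlorine together, so the compounds shown leave open which of the two loss matters, or whether both do. A phenylcarbonyl group or a 2-chlorobenzyl group in the same place would separate the two.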